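Replacing Fluoro with Hydroxyethyl on the Aryl Sulfonamide

A few compounds are considered here, and "the series" means these few. Any claim that something is new, unique, unknown or untested is made for them only; others in the source may bear on it.

Compound 1, `CCN(c1ccccc1C)S(=O)(=O)c1cc(Cl)ccc1Cl`, in an ADME assay on A549 cells (Homo sapiens) for cytotoxicity, read by MTT assay (a lower number here means that less compound is tolerated, a higher number that more compound is tolerated), gives > 25000 nM, a limit of the assay.
Compound 2, `CCN(c1ccccc1Cl)S(=O)(=O)c1cc(Cl)ccc1Cl`, gives > 5000 nM, also a limit.
Compound 3, `CCN(c1ccc(F)cc1)S(=O)(=O)c1cc(Cl)ccc1Cl`, gives > 5000 nM, again a limit.

Compound 3 therefore stands only at a limit, with no number of its own; it shares the limit of > 5000 nM in this assay, at which 2 of the 3 values shown sit, with compound 2, while compound 1 sits at the limit of > 25000 nM in this assay, at which 1 of the 3 values shown sits.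

Compound 4, `CCN(c1ccc(CCO)cc1)S(=O)(=O)c1cc(Cl)ccc1Cl`, differs from compound 3 by 2-hydroxyethyl in place of fluoro on an aromatic carbon. Going by the values given here, the steps that bear on this change, a step that the two limits leave unreadable from compound 1 to compound 3 and a step that the two limits leave unreadable from compound 2 to compound 3, cannot be read in size, so no direction beyond the scatter can be stated for this assay. Compound 4 is expected to be tolerated to a similarly high concentration, estimated at 20000 nM, between 5000 nM and 60000 nM, which is an expected step that the limit leaves unreadable from compound 3 to compound 4.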

Compound 4, half-maximal cytotoxic concentration: > 25000 nM
Compound 4: only a limit was reported (the forecaster's own chance of this, stated with the estimate: 70%); middle value at least 1.2-fold (0.09 log units) away from the limit.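

In this assay compound 3 stays at a limit, > 5000 nM. Going by these compounds alone, compound 4 also stays at a limit, > 25000 nM, and no step between the two can be read. The compounds shown leave open the actual concentration at which any of them becomes toxic to these cells.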